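Replacing the 2-oxopyrrolidin-1-yl group of compound 2

The compounds below may be only part of what the source reports. "The series", "measured", "known", "first", "only" and "open" are said of these compounds alone.

Measured in a physicochemical assay for lipophilicity, using the shake flask method, in phosphate buffer, measured as octanol-water partition, with a stated time of 30 min, at pH 7.4; a higher number here means a more lipophilic compound, a lower number a more polar compound:
Compound 1 `COCCC(=O)Nc1cnc(NCc2c(F)ccc3c2CCO3)n2cnnc12`: 1.4
Compound 2 `O=C1CCCN1c1cnc(NCc2c(F)ccc3c2CCO3)n2cnnc12`: 1.3

In this assay compound 2 stands at 1.3, within the scatter of compound 1, so the pair gives a single level rather than an order. The next compound, compound 3 `CN(c1cccnc1)c1cnc(NCc2c(F)ccc3c2CCO3)n2cnnc12`, carries methyl(pyridin-3-yl)amino in place of 2-oxopyrrolidin-1-yl on an aromatic carbon. Among the measured compounds shown here, only one measured step bears on this change, a number 0.10 log units lower from compound 1 to compound 2 (within the scatter). For the measured compounds named here, it exchanged two carbonyl-bearing groups at the same place, whereas the entering group here has no carbonyl and appears in no measured compound, so that step is a weak guide. A larger move upward is expected, and the expected step is a number 0.80 log units higher from compound 2 to compound 3 (beyond the scatter). For compound 3 the estimated value is 2.1, with an expected range of 1.6 to 2.6.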

Compound 3, distribution coefficient: 2.6
The estimate for compound 3 lay 0.50 log units below the measured number; measured number inside the range.
By their numbers in this assay, from the lowest: compounds 2 and 1 (each within the scatter of the next); then compound 3.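

In this assay, the two carbonyl-bearing groups had given only a single level at this aromatic carbon, whereas methyl(pyridin-3-yl)amino gives a number 1.30 log units higher from compound 2 to compound 3 (beyond the scatter) and, measured against the open-chain amide, a number 1.20 log units higher from compound 1 to compound 3 (beyond the scatter). Both steps are large and beyond the scatter, so the level shared by compound 1 and compound 2 does not hold for every group at this position. Nothing measured here accounts for the rise.

The compounds shown do not separate the share of the pyridin-3-yl ring from that of the methyl on the linking nitrogen. They also leave open where a phenyl group on the same nitrogen, or a simple dimethylamino group with no ring at all, would fall relative to compound 2 and compound 3.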